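Thiomorpholine thiosemicarbazones: the ring methyl removed

A few compounds are considered here, and "the series" means these few. Any claim that something is new, unique, unknown or untested is made for them only; others in the source may bear on it.

Compound 3 `Cc1ccnc(/C(N)=N/NC(=S)N2CCSCC2)c1` gives 79.6% in a functional assay on A-431 cells (Homo sapiens) for cytotoxicity, read by MTT assay, with a stated time of 72 h, tested at 100 uM; a lower number here means less inhibition of growth, a higher number more inhibition of growth at the concentration tested. This is the lowest of the three numbers recorded, yet it lies within the scatter of both others: compound 2 `Cc1cccc(/C(N)=N/NC(=S)N2CCSCC2)n1` gives 80.7% and compound 1 `N/C(=N\NC(=S)N1CCOCC1)c1ccccn1` gives 84.6% in this assay. No two of these values differ beyond the usual scatter, so no ordering among them can be read. Compound 4 `N/C(=N\NC(=S)N1CCSCC1)c1ccccn1` differs from compound 3 by hydrogen in place of methyl on an aromatic carbon. Among the compounds with values here, no measured pair isolates this change, and the three recorded values sit close together. The step from compound 3 to compound 4 is therefore expected to be a number 1.4 percentage points higher from compound 3 to compound 4 (within the scatter), not beyond the scatter in either direction. Compound 4 is estimated at 81% in this assay, within the range 71% to 91%.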

Compound 4, percent growth inhibition at one concentration: 80.8%
Compound 4: the middle estimate sits 0.2 percentage points above what was measured, and the stated range covers the measured number.
By their numbers in this assay, from the lowest: compounds 3, 2, 4 and 1 (each within the scatter of the next).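

In this assay, hydrogen in place of methyl on an aromatic carbon gives a number 1.2 percentage points higher from compound 3 to compound 4 (within the scatter) and a number 0.1 percentage points higher from compound 2 to compound 4 (within the scatter), so neither methyl placement separates from the unsubstituted ring. Thiomorpholin-4-yl in place of morpholin-4-yl on a thiocarbonyl carbon gives a number 3.8 percentage points lower from compound 1 to compound 4 (within the scatter), so this exchange also stays within the scatter. No supporting evidence bears on these results. Open, on these data alone, is whether an amine, a carboxylic acid or a longer chain in place of the methyl would give a step beyond the scatter.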